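Propyl for Isopropyl on the Ring Nitrogen of Compound 1

A few compounds are considered here, and "the series" means these few. Any claim that something is new, unique, unknown or untested is made for them only; others in the source may bear on it.

Of the compounds shown here, three have so far been measured in a functional assay with Alpha-1B adrenergic receptor (Homo sapiens) as the target, read by calcium flux; a higher number here means a larger maximal response, a lower number a smaller maximal response. Compound 1 `CC(C)n1ncnc1-c1ccccc1NCC1=NCCN1` gives 0%. Compound 3 `CCn1nccc1-c1ccccc1NCC1=NCCN1` gives 0%, level with compound 1 at the digits shown; these two are together the lowest of the three numbers, and the gap between them lies within the scatter. Furthest from compound 1 stands compound 2 `c1ccc(-c2cn[nH]c2)c(NCC2=NCCN2)c1`, which gives 72%, a gap beyond the scatter.

Compound 4 `CCCn1ncnc1-c1ccccc1NCC1=NCCN1` has not yet been measured in this assay. It differs from compound 1 in a single place: propyl in place of isopropyl on an aromatic nitrogen. The two compounds have the same atoms, joined differently.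

Going by the values given here, no step between two measured compounds that differ in one place is available to set the size of such a change. What can be said is that both compounds carrying a small alkyl group on the aromatic nitrogen of the shared core give low maximal responses: compound 1 gives 0% and compound 3 gives 0%. Against that background, the exchange of isopropyl for propyl is expected to produce at most a small step, with a number 5 percentage points higher from compound 1 to compound 4 (within the scatter) lying within the scatter or only just beyond it. Compound 4 is therefore estimated at 5%, in a range from 0% to 25%.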

Compound 4, largest response reached (reported as maximal response), in percent of the reference or control that the assay uses: 74%
For compound 4 the middle estimate is 69 percentage points below the measured one; measured number above the stated range.
By their numbers in this assay, from the lowest: compounds 1 and 3 (each within the scatter of the next); then compounds 2 and 4 (each within the scatter of the next).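

In this assay, going by these compounds alone, propyl in place of isopropyl on the aromatic nitrogen gives a number 74 percentage points higher from compound 1 to compound 4 (beyond the scatter), the first step at this position that can be read. Isopropyl and propyl both have 3 heavy atoms, all carbon, with no ring and no hydrogen-bond donors or acceptors, so the two compounds differ only in how that chain is joined. The low number of compound 1 therefore does not hold for every small alkyl group at this place on the shared core, and the maximal response here can change strongly with a change of connectivity alone, without any change in atoms.

Going by these compounds, whether a longer chain such as butyl, or a cyclopropylmethyl group, on this nitrogen would keep the response of compound 4 or lose it remains open, as does whether an unbranched chain would have the same effect on the core of compound 3. The data shown offer no independent measurement that would account for the size of this step.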